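Swapping an Acetyl for a Methylsulfonyl on the Chain

This account rests on a few compounds, and the source may have more. Where it says the series, first, only, none or still open, it means among the compounds named here.

Compound 1 `CC(=O)NCC[C@@H]1C[C@@H](c2ccc(F)c(F)c2)[C@H](NC(=O)c2cc(-c3c(Cl)cnn3C)c(Cl)o2)CN1` — 2.49 nM
Compound 2 `Cn1ncc(Cl)c1-c1cc(C(=O)N[C@@H]2CN[C@H](CC(=O)NC3CCC3)C[C@H]2c2ccc(Cl)c(Cl)c2)oc1Cl` — 7.98 nM
Compound 3 `Cn1ncc(Cl)c1-c1cc(C(=O)N[C@@H]2CN[C@H](CC(O)CO)C[C@H]2c2ccc(Cl)c(Cl)c2)oc1Cl` — 3.79 nM

Three compounds share one core and differ in what the saturated chain carries at its end. In an assay for inhibition of RAC-alpha serine/threonine-protein kinase (Homo sapiens), read by HTRF, with a stated time of 1 h (a lower number here means a stronger inhibitor, a higher number a weaker inhibitor), compound 1 gives 2.49 nM, the lowest of the three numbers. Compound 3 gives 3.79 nM, a number within the scatter of compound 1, while compound 2 gives 7.98 nM, a higher number beyond the scatter. Among the measured compounds shown here, the only step measured between compounds that differ in one place, a 2.1-fold lower number from compound 2 to compound 3 (0.32 log units; beyond the scatter), shows that exchanging the group at the end of that chain moves this assay only modestly.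

Compound 4 `Cn1ncc(Cl)c1-c1cc(C(=O)N[C@@H]2CN[C@H](CCNS(C)(=O)=O)C[C@H]2c2ccc(F)c(F)c2)oc1Cl` differs from compound 1 as follows: methylsulfonyl in place of acetyl on an amine nitrogen. For the measured compounds named here, this exchange sits on the same chain as the step from compound 2 to compound 3 but is a different exchange, so no measured step speaks to it directly; the modest size of a 2.1-fold lower number from compound 2 to compound 3 (0.32 log units; beyond the scatter) is the only guide. A small step is therefore expected, a 1.2-fold higher number from compound 1 to compound 4 (0.08 log units; within the scatter), with no firm direction. Compound 4 is estimated at 3 nM, with a range from 1.2 nM to 8 nM.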

Compound 4, half-maximal inhibitory concentration: 3.29 nM
For compound 4 the middle estimate is 1.1-fold (0.04 log units) below the measured one, and the stated range covers the measured number.
By their numbers in this assay, from the lowest: compounds 1, 4 and 3 (each within the scatter of the next); then compound 2.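

In this assay, among the compounds shown here, the step of a 1.3-fold higher number from compound 1 to compound 4 (0.12 log units; within the scatter) is the first measured exchange made directly on the amine nitrogen of this chain, and it shows that acetyl and methylsulfonyl cannot be told apart here. The earlier step concerned other groups at the chain end, whereas this one shows that a group with more heavy atoms and more hydrogen-bond acceptors can stand on this nitrogen with the number staying within the scatter. No measurement is at hand that could say why the two groups read alike.

These two groups are both neutral, so a free amine or a carboxylic acid at the end of the chain remains an open case. As far as these compounds go, whether a longer chain would be accepted as readily also remains open.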